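This account rests on a few compounds, and the source may have more. Where it says the series, first, only, none or still open, it means among the compounds named here.

Measured so far:
- compound 1, `C=CC(=O)NCc1coc(-c2c(N)ncnc2Nc2ccc(OCc3ccccn3)c(F)c2)n1`: in an in vitro ADME assay on microsomes from liver (Canis lupus familiaris) for metabolic stability, tested at 5 uM (on this read-out higher numbers stand for a longer-lived compound and lower numbers for a shorter-lived compound), compound 1 gives 0.733 h.
- compound 2, `C=CC(=O)NCc1coc(-c2c(N)ncnc2Nc2ccc(Oc3cccc(F)c3)c(Cl)c2)n1`: in this assay compound 2 gives > 1.66 h, which is a limit of the assay and not a number.

Compound 2 therefore stands at the upper end of what the assay reports, as the limit of > 1.66 h in this assay, at which 1 of the 2 values shown sits, shows, while compound 1 gives a number well inside the range. Among the compounds with values here, no step between measured compounds is available, since the two differ in more than one place; the two values only show that compound 1 is the shorter-lived of the pair.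

The next compound, compound 3, `C=CC(=O)NCc1coc(-c2c(N)ncnc2Nc2ccc(F)c(Cl)c2)n1`, follows from compound 2 by fluoro in place of 3-fluorophenoxy on an aromatic carbon. Within the data shown here, with only one measured number and one limit to go on, the expectation for this step is a fall in this assay of modest size, which may or may not exceed the scatter. Compound 3 is thus estimated at 1 h, within 0.4 h to 2.5 h. That estimate means a step of an at least 1.6-fold lower number from compound 2 to compound 3 (0.22 log units; that floor lies within the scatter), expected to bring compound 3 back below the limit.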

Compound 3, half-life: 0.15 h
Compound 3: the middle estimate sits 6.7-fold (0.82 log units) above what was measured, and the stated range ends above it.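

In this assay, fluoro in place of 3-fluorophenoxy on this aromatic carbon, ortho to a chloro group, gives an at least 11-fold lower number from compound 2 to compound 3 (1.04 log units; beyond the scatter). Within the data shown here, this pair provides the only reading of a single place so far, and it shows that, with the chloro group and the rest of the molecule held constant, the group on this carbon can move the half-life well beyond the scatter. The step gives only a minimum size, and its full extent stays unknown, because compound 2 is recorded only as a limit: the limit of > 1.66 h in this assay, at which 1 of the 3 values shown sits.

The pair does not separate the contributions of the aromatic ring, the oxygen and the overall size of 3-fluorophenoxy, so the change cannot yet be assigned to any one of them. Nor do the compounds shown indicate how methoxy, benzyloxy or an amine on this carbon would read in this assay, and compound 1 differs from both compound 2 and compound 3 in more than one place, so it cannot settle the question.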